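Hydroxy at the chain end: expected cytotoxicity of compound 4

A few compounds are considered here, and "the series" means these few. Any claim that something is new, unique, unknown or untested is made for them only; others in the source may bear on it.

Compound 1, `CN(c1ccnc(Nc2ccc(C#N)cc2)n1)c1c(F)cc(-c2ccc(C#N)cc2)cc1F`, gives 148000 nM in an ADME assay on MT4 cells (Homo sapiens) for cytotoxicity, read by MTT assay, with a stated time of 5 days; on this read-out lower numbers stand for higher toxicity in this test and higher numbers for lower toxicity in this test.
Compound 2, `CCN(c1ccnc(Nc2ccc(C#N)cc2)n1)c1c(F)cc(-c2ccc(C#N)cc2)cc1F`, gives 105000 nM.
Compound 3, `CCCCN(c1ccnc(Nc2ccc(C#N)cc2)n1)c1c(F)cc(-c2ccc(C#N)cc2)cc1F`, gives 211000 nM.

Compound 3 holds the highest of the three numbers, but the steps of a 1.4-fold higher number from compound 1 to compound 3 (0.15 log units; within the scatter) and a 2.0-fold higher number from compound 2 to compound 3 (0.30 log units; within the scatter) both stay within the scatter, so the three compounds cannot be told apart on this read-out.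

Compound 4, `N#Cc1ccc(Nc2nccc(N(CCCO)c3c(F)cc(-c4ccc(C#N)cc4)cc3F)n2)cc1`, has not yet been measured. (hydroxy in place of methyl on a saturated chain carbon, three bonds along the chain from a nitrogen on an aromatic ring). The measured steps bear on this change only loosely: each of them varies the same chain, as in a 1.4-fold lower number from compound 1 to compound 2 (0.15 log units; within the scatter), a 1.4-fold higher number from compound 1 to compound 3 (0.15 log units; within the scatter) and a 2.0-fold higher number from compound 2 to compound 3 (0.30 log units; within the scatter), and none of them leaves the scatter. None of them puts a hydroxy into the chain, so there is no direct guide for what a hydroxy does here. The only lesson available is that changes to this chain have so far left the number where it was, and the same is expected for compound 4, namely a 1.1-fold lower number from compound 3 to compound 4 (0.02 log units; within the scatter).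

Compound 4 is therefore estimated at 200000 nM, with a likely range from 100000 nM to 400000 nM.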

Compound 4, half-maximal cytotoxic concentration: 68000 nM
Compound 4: the middle estimate sits 2.9-fold (0.47 log units) above what was measured; the measured number lies below the stated range.
By their numbers in this assay, from the lowest: compounds 4, 2, 1 and 3 (each within the scatter of the next, the first and the last beyond it).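

In this assay, putting hydroxy in place of the methyl at the end of the butyl chain produces a shift that the earlier chain changes did not: a 3.1-fold lower number from compound 3 to compound 4 (0.49 log units; beyond the scatter) is a modest step, but it lies beyond the usual scatter. The comparison with the shorter chain agrees, as a 2.2-fold lower number from compound 1 to compound 4 (0.34 log units; beyond the scatter) is also beyond the scatter, so this position is not wholly indifferent to what is placed on the chain, and on this read-out a lower number stands for higher toxicity. The picture stays limited, however, since a 1.5-fold lower number from compound 2 to compound 4 (0.19 log units; within the scatter) is within the scatter and compound 4 cannot be told apart from compound 2, while no measurement at hand explains why this single change of atom moves the number.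

The compounds shown leave open whether the shift depends on how far the hydroxy sits along the chain, as a 2-hydroxyethyl chain or a hydroxy-ended chain longer than 3-hydroxypropyl would show. They also leave open whether an amine or a carboxylic acid at the same chain end would move the number in the same direction as the hydroxy does.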